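Triazole to Tetrazole on the Sulfur Linker

A few compounds are considered here, and "the series" means these few. Any claim that something is new, unique, unknown or untested is made for them only; others in the source may bear on it.

Compound 1, `Cn1c(-c2ccc(NC(=O)CSc3nc4ccccc4o3)cc2)nc(-c2ccccc2)c1-c1ccccc1`, gives 79.3% in a functional assay on HT-29 cells (Homo sapiens) for cytotoxicity, read by MTT assay, with a stated time of 24 h, tested at 32 ug/mL; a higher number here means a stronger effect of the compound at the concentration tested, a lower number a weaker effect.
Compound 2, `Cn1cnnc1SCC(=O)Nc1ccc(-c2nc(-c3ccccc3)c(-c3ccccc3)n2C)cc1`, gives 86.1% in this assay.

For the measured compounds named here, compound 2 holds the higher of the two numbers measured so far, though its nearest neighbour, compound 1, sits close enough that the two cannot be separated, since the only measured step, a number 6.8 percentage points higher from compound 1 to compound 2 (within the scatter), is within the scatter. That step exchanged one five-membered heteroaryl group on the sulfur for another, and the read-out barely moved.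

Compound 3, `Cn1nnnc1SCC(=O)Nc1ccc(-c2nc(-c3ccccc3)c(-c3ccccc3)n2C)cc1`, has not been measured. It differs from compound 2 only at the sulfur:

1-methyl-1H-tetrazol-5-yl in place of 4-methyl-4H-1,2,4-triazol-3-yl on a sulfur

Going by the values given here, the one step that bears on this change is the heteroaryl swap from compound 1 to compound 2, and it was within the scatter. A second swap of the same kind, again a small five-membered aromatic ring on the sulfur, is therefore expected to leave the read-out where it is. The expected change is a number 2.1 percentage points lower from compound 2 to compound 3 (within the scatter), nothing beyond the scatter. Compound 3 is accordingly estimated at 84%, with a range from 70% to 95%.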

Compound 3, a percentage reported as activity, at one concentration (the size of the read-out at that concentration, not a potency): 84%
Compound 3: middle estimate and measured number agree at the digits printed, within the range that was stated.
By their numbers in this assay, from the lowest: compounds 1, 3 and 2 (each within the scatter of the next).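

The exchange of 4-methyl-4H-1,2,4-triazol-3-yl for 1-methyl-1H-tetrazol-5-yl on the sulfur gives a number 2.1 percentage points lower from compound 2 to compound 3 (within the scatter), and the exchange of 1,3-benzoxazol-2-yl for the same group gives a number 4.7 percentage points higher from compound 1 to compound 3 (within the scatter). For the compounds shown here, with a third group in place, one that has 4 hetero atoms in its five-membered aromatic ring, compounds 1, 2 and 3 still cannot be told apart in this assay, so three different aromatic groups on this sulfur now give a single level of read-out rather than the one pair seen before. Nothing available here accounts for that insensitivity or says what the read-out reflects at this position.

Going by these compounds, what remains open is whether this sulfur needs an aromatic group at all, since all three compounds carry one, and a plain methyl group, a chain ending in an amine or a carboxylic acid would put that to the test. On these data alone, these numbers also come from a single concentration, so whether any of the three compounds would have a stronger or weaker effect than the others at another concentration remains open as well.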